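From 3-Methylphenyl to 2,4-Difluorophenyl on a Shared Core

The source may hold more compounds than are shown below. What is called first, only, known or untested is meant among the compounds shown, and "the series" means these compounds.

compound 1, `CC#CC(CC(=O)O)c1ccc(OCc2ccn3cc(-c4cccc(C)c4)nc3c2)cc1`: 1510 nM
compound 2, `CC#CC(CC(=O)O)c1ccc(OCc2ccc3nc(-c4ccccc4)cn3c2)cc1`: 979 nM
compound 3, `CC#CC(CC(=O)O)c1ccc(OCc2ccc3nc(-c4ccc(C(F)(F)F)cc4)cn3c2)cc1`: 558 nM

All three compounds were tested in an assay on isolated protein for agonist activity at Free fatty acid receptor 1 (Homo sapiens); a lower number here means that less compound is needed, a higher number that more compound is needed for the effect. Compound 1 gives the highest of the three numbers; its nearest neighbour is compound 2, which lies within the scatter of it, while compound 3 lies beyond the scatter below it. Compound 4, `CC#CC(CC(=O)O)c1ccc(OCc2ccn3cc(-c4ccc(F)cc4F)nc3c2)cc1`, has not yet been measured. It differs from compound 1 in one place: 2,4-difluorophenyl in place of 3-methylphenyl on an aromatic carbon. Among the measured compounds shown here, the only measured step, a 1.8-fold lower number from compound 2 to compound 3 (0.24 log units; within the scatter), concerns a different change on a differently built version of the shared core and itself falls within the scatter. For the measured compounds named here, no measured step therefore bears directly on the exchange that separates compound 1 from compound 4, and nothing in the data points to a large move in either direction. The expected step is accordingly small: a 1.4-fold lower number from compound 1 to compound 4 (0.14 log units; within the scatter). The estimate for compound 4 in this assay is 1100 nM, with a range from 400 nM to 3000 nM.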

Compound 4, half-maximal effective concentration: 792 nM
Estimate against measurement, compound 4: 1.4-fold (0.14 log units) above, and the stated range covers the measured number.
By their numbers in this assay, from the lowest: compounds 3, 4, 2 and 1 (each within the scatter of the next, the first and the last beyond it).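

Among the compounds shown here, at this aromatic carbon of the five-membered aromatic ring, 2,4-difluorophenyl in place of 3-methylphenyl gives a 1.9-fold lower number from compound 1 to compound 4 (0.28 log units; within the scatter) in this assay, the only exchange that can be read directly on this version of the shared core. The position therefore accepts a phenyl ring with two fluorines in place of one with a methyl, and the two compounds cannot be told apart in this assay. Nothing available explains why these two groups read alike.

From the compounds shown here alone, it remains open whether a single fluorine, as in 4-fluorophenyl, would give a similar reading, or whether an amine or a carboxylic acid on this phenyl ring would shift the number beyond the scatter. Whether trifluoromethyl would behave here as it does on the differently built core also stays unresolved.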